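The source may hold more compounds than are shown below. What is called first, only, known or untested is meant among the compounds shown, and "the series" means these compounds.

Measured so far:

compound 1 `CCNC(=O)Nc1ccc(-c2nc3n(Cc4c(F)cccc4F)cc(C(=O)OCC)c(=O)n3c2CN(CC(=O)NCc2cn(CCOCCN=[N+]=[N-])nn2)Cc2ccccc2)cc1` gives 525 nM
compound 2 `CCNC(=O)Nc1ccc(-c2nc3n(Cc4c(F)cccc4F)cc(C(=O)OCC)c(=O)n3c2CN(CC(=O)NCc2cn(CCN=[N+]=[N-])nn2)Cc2ccccc2)cc1` gives 724 nM
compound 3 `CCOC(=O)c1cn(Cc2c(F)cccc2F)c2nc(-c3ccc(NC(=O)NCc4cn(CCOCCN=[N+]=[N-])nn4)cc3)c(CN(C)Cc3ccccc3)n2c1=O` gives 3630 nM

These three compounds were tested in a functional assay on CHO cells for antagonist activity at Gonadotropin-releasing hormone receptor (Homo sapiens), read by a luciferase reporter, with a stated time of 30 min; a higher number here means a weaker inhibitor, a lower number a stronger inhibitor. Compound 1 and compound 2 share one core and differ only in one place: the change 2-azidoethoxy in place of azido on a saturated chain carbon, two bonds along the chain from an aromatic nitrogen gave a 1.4-fold lower number from compound 2 to compound 1 (0.14 log units; within the scatter), so the two are not distinguishable within this assay's scatter. Compound 3 stands on a different core; the difference between the core of compound 3 and the core of compound 2 is not broken down here. In this assay compound 3 gives the highest number of the three, beyond the scatter from both compound 1 and compound 2.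

Compound 4 `CCOC(=O)c1cn(Cc2c(F)cccc2F)c2nc(-c3ccc(NC(=O)NCc4cn(CCOCCOCCN=[N+]=[N-])nn4)cc3)c(CN(C)Cc3ccccc3)n2c1=O` has not yet been measured. It is made from compound 3 by the change (2-azidoethoxy in place of azido on a saturated chain carbon, two bonds along the chain from an oxygen on a saturated carbon). This is the same kind of change that turned compound 2 into compound 1, but not the same: there the place was two bonds along the chain from an aromatic nitrogen, while here it is two bonds along the chain from an oxygen on a saturated carbon, so the chain grows at a point already one link further from the ring.

Because the earlier step read a 1.4-fold lower number from compound 2 to compound 1 (0.14 log units; within the scatter), a similarly small step is expected from compound 3 to compound 4, a 1.2-fold lower number from compound 3 to compound 4 (0.08 log units; within the scatter), within the scatter. Compound 4 is therefore estimated at 3000 nM in this assay, with a plausible range from 1200 nM to 7500 nM; this rests on one pair only and remains a rough expectation.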

Compound 4, half-maximal inhibitory concentration: 2400 nM
Compound 4: middle estimate off by 1.3-fold (0.10 log units), on the high side; the measured number falls inside the stated range.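

In this assay, putting 2-azidoethoxy in place of azido at the end of the chain gave a 1.5-fold lower number from compound 3 to compound 4 (0.18 log units; within the scatter), so on this core the longer chain leaves the inhibition reading without a change that can be told from scatter. Set beside the earlier step, the new one agrees with it: the same change on two cores in this assay, a 1.4-fold lower number (0.14 log units; within the scatter) from compound 2 to compound 1 and a 1.5-fold lower number (0.18 log units; within the scatter) from compound 3 to compound 4, 1.1-fold (0.04 log units) apart, within the scatter of two such steps. This shows that, for these two pairs, the change carried from one core to the other with the same small outcome, though the place differs slightly, being two bonds along the chain from an aromatic nitrogen in one pair and two bonds along the chain from an oxygen on a saturated carbon in the other; it does not show that the same would hold on a third core, and two steps this small test the carrying of an effect only weakly, with one pair standing for each core.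

The compounds shown leave open how the number would respond if the azido end gave way to another group, such as an amine or a carboxylic acid, or if the chain grew longer still. Also open, going by these compounds, is how the 2-(2-azidoethoxy)ethoxy chain of compound 4 would read on the core of compound 1.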